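The compounds below may be only part of what the source reports. "The series", "measured", "known", "first", "only" and "open" are said of these compounds alone.

Measured compounds:
- compound 1, `CCCS(=O)(=O)Nc1ccc(F)c(C(=O)Nc2cnc3ccnn3c2)c1F`: 11.4 10^-6 cm/s
- compound 2, `CCCS(=O)(=O)Nc1ccc(F)c(C(=O)Nc2cnc3[nH]cnc3c2)c1F`: 0.6 10^-6 cm/s

In an ADME assay on Caco-2 cells (Homo sapiens) for permeability, in the apical to basolateral direction (a higher number here means that the compound crosses the layer faster, a lower number that the compound crosses the layer more slowly), compound 1 gives 11.4 10^-6 cm/s, while compound 2 gives 0.6 10^-6 cm/s. Among the compounds with values here, compound 2 thus stands at the lowest of the two numbers, and its only neighbour is compound 1; the one step measured so far, a 19-fold lower number from compound 1 to compound 2 (1.28 log units; beyond the scatter), is the exchange of the fused ring system on the amide-type nitrogen.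

Compound 3, `CCCS(=O)(=O)Nc1ccc(F)c(C(=O)Nc2cnc3[nH]c(-c4ccc(Br)cc4)nc3c2)c1F`, differs from compound 2 by 4-bromophenyl in place of hydrogen on an aromatic carbon. Within the data shown here, no measured step touches this change: the single step available concerns the fused ring system itself, not a substituent on it, so it offers no direct guide to the size or direction of the effect in this assay. What remains is the standing of compound 2. Because compound 2 sits at 0.6 10^-6 cm/s, the lowest point of the measured range, a further fall is expected to be small, and a moderate rise is taken as the more likely outcome. The step expected is a 3.3-fold higher number from compound 2 to compound 3 (0.52 log units; beyond the scatter). Compound 3 is therefore estimated at 2 10^-6 cm/s, within a range from 0.5 10^-6 cm/s to 8 10^-6 cm/s.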

Compound 3, apparent permeability: 1.3 10^-6 cm/s
Compound 3: the middle estimate sits 1.5-fold (0.19 log units) above what was measured, within the range that was stated.
By their numbers in this assay, from the lowest: compound 2; then compound 3; then compound 1.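

In this assay, within the data shown here, 4-bromophenyl in place of hydrogen on the aromatic carbon between two ring nitrogen atoms gives a 2.2-fold higher number from compound 2 to compound 3 (0.34 log units; beyond the scatter), the first reading of a substituent at this position rather than an exchange of the fused ring system itself. The step is modest and beyond the scatter, so this carbon carries 4-bromophenyl with a measurable rise in the number, although the change is much smaller than the large one printed for the ring exchange, a 19-fold lower number from compound 1 to compound 2 (1.28 log units; beyond the scatter). Nothing at hand bears on the origin of the rise from hydrogen to 4-bromophenyl.

The two compounds that differ at this carbon cannot separate the contribution of the six-membered aromatic ring from that of the bromine, and a plain phenyl or a 4-chlorophenyl at the same place would be needed to draw that line. As far as these compounds go, it also remains open how the number would respond to a small methyl on this carbon, or to a piperazine or a carboxylic acid carried on the phenyl ring.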